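Fluoro for chloro on the shared core

The source may report more compounds than this note shows. Statements on the series, on what has been measured and on what is new or still open speak of the compounds shown alone.

Compound 1 `O=S(=O)(c1cccc(F)c1)c1cn(C2CCNC2)c2cc(Cl)ccc12` gives 72 nM in an assay on HeLa cells for displacement of a labelled ligand from 5-hydroxytryptamine receptor 6 (Homo sapiens), with a stated time of 2 h (on this read-out higher numbers stand for weaker inhibition and lower numbers for stronger inhibition), the higher of the two numbers in hand. For the measured compounds named here, compound 2 `O=S(=O)(c1cccc(F)c1)c1cn(C2CCCNC2)c2ccc(F)cc12` gives 4 nM in this assay, a gap beyond the scatter, but compound 2 differs from compound 1 in more than one place, so no single step joins them. Compound 3 `O=S(=O)(c1cccc(F)c1)c1cn(C2CCNC2)c2cc(F)ccc12` is not yet measured in this assay. From compound 1 it changes by fluoro in place of chloro on an aromatic carbon. Compound 2 also carries fluoro, yet its second difference keeps its value from being read across directly. A modest step toward a lower number is expected, a 1.8-fold lower number from compound 1 to compound 3 (0.26 log units; within the scatter). Compound 3 is estimated at 40 nM, within 12 nM to 130 nM.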

Compound 3, inhibition constant: 18 nM
The estimate for compound 3 lay 2.2-fold (0.35 log units) above the measured number; the measured number falls inside the stated range.
By their numbers in this assay, from the lowest: compound 2; then compound 3; then compound 1.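

On the shared core, this aromatic carbon is sensitive to the choice of halogen: fluoro in place of chloro gives a 4.0-fold lower number from compound 1 to compound 3 (0.60 log units; beyond the scatter) in this assay and lies beyond the scatter. For the compounds shown here, this is the first single-place reading, which the pair of compound 1 and compound 2 could not provide. Nothing in hand accounts for the size of this step.

On these data alone, whether the number tracks halogens alone remains open. A methoxy group, a nitrile or plain hydrogen on this aromatic carbon would test that.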